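This account rests on a few compounds, and the source may have more. Where it says the series, first, only, none or still open, it means among the compounds named here.

Working notes on the urea series in an ADME assay on NCM460 cells (Homo sapiens) for cytotoxicity, read by MTT assay, with a stated time of 72 h, in the presence of a further agent that is not named here; a lower number here means that less compound is needed, a higher number that more compound is needed for the effect.

Within the data shown here, two ureas carry numbers so far. Compound 1 `O=C(Nc1cc(Cl)nc(Cl)c1)Nc1cc2ccccn2n1` pairs the dichloropyridine urea with a bicyclic partner; in this assay compound 1 gives 10200 nM. Compound 2 `O=C(Nc1cc(Cl)nc(Cl)c1)Nc1cc(Cl)nc(Cl)c1` carries the same dichloropyridine on both sides of the urea; in this assay compound 2 gives 9440 nM. Among the measured compounds shown here, compound 2 stands alongside compound 1: the two numbers lie within the usual scatter of each other, so nothing separates them on the evidence in hand, and no step between measured compounds is available.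

Compound 3 `CC(C)Oc1cc(NC(=O)Nc2cc(Cl)nc(Cl)c2)cc(Cl)n1` is the next entry. It differs from compound 2 in one place: isopropoxy in place of chloro on an aromatic carbon. For the measured compounds named here, no measured pair shows what this exchange does, so the expectation rests on compound 2 alone. The step from compound 2 to compound 3 is expected to be small, a 1.0-fold lower number from compound 2 to compound 3 (0.02 log units; within the scatter), without a direction that can be argued for beyond the scatter. For compound 3 in this assay a value of 9000 nM is estimated, with a range from 3000 nM to 30000 nM.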

Compound 3, half-maximal effective concentration: 21100 nM
Beside the measured number, compound 3's estimate is 2.3-fold (0.37 log units) below it; the measured number falls inside the stated range.
By their numbers in this assay, from the lowest: compounds 2 and 1 (each within the scatter of the next); then compound 3.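

At this place, on an aromatic carbon of the six-membered aromatic ring with 1 nitrogen, next to the ring nitrogen, the series gives its first readable step in this assay, where isopropoxy in place of chloro produces a 2.2-fold higher number from compound 2 to compound 3 (0.35 log units; beyond the scatter) on a single exchange. Among these compounds, the two earlier ureas could not show this, as their numbers lie within the scatter of each other and no step joined them, so this position is the first where a change of group is seen to move the number, if only modestly and on one pair. What lies behind the shift cannot be said, as nothing measured on these compounds bears on it.

On these data alone, only chloro and isopropoxy have been seen at this place, so it remains open whether a methoxy group, an amine or a longer alkoxy chain there would carry the number further, leave it where it stands or bring it back. As far as these compounds go, it is equally open whether isopropoxy would give a similar step on the dichloropyridine of compound 1, where the partner across the urea is bicyclic.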